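The source may report more compounds than this note shows. Statements on the series, on what has been measured and on what is new or still open speak of the compounds shown alone.

Compound 1 `O=C(Nc1ccccc1)c1ccc(-c2ncccc2C(F)(F)F)cc1` carries in a functional assay for antagonist activity at transient receptor potential cation channel subfamily V member 1 (Rattus norvegicus) (on this read-out higher numbers stand for weaker inhibition and lower numbers for stronger inhibition), only the entry "not determined" (no result reported), so no result is available for it there. Compound 2 `Cc1cccnc1-c1ccc(C(=O)Nc2ccc(F)cc2)cc1` reaches only a limit of the assay there, > 4000 nM. Among the compounds with values here, compound 3 `CC(C)(C)c1ccc(NC(=O)c2ccc(-c3ncccc3C#N)cc2)cc1` is the only entry with a number in this assay, where compound 3 gives 13 nM. The other two entries give no number, so compound 3 has no measured neighbour against which a step could be sized. Compound 4 `CC(C)(C)c1ccc(NC(=O)c2ccc(-c3ncccc3C(=N)N)cc2)cc1` differs from compound 3 by a group of 3 heavy atoms (1 carbon, 2 nitrogen; no ring) in place of a group of 2 heavy atoms (1 carbon, 1 nitrogen; no ring), on an aromatic carbon. Within the data shown here, no measured step covers this change, so the expected step of a 6.2-fold higher number from compound 3 to compound 4 (0.79 log units; beyond the scatter) toward weaker inhibition in this assay rests on no comparison and is held modest. Compound 4 is accordingly expected near 80 nM, within 15 nM to 500 nM.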

Compound 4, half-maximal inhibitory concentration: > 4000 nM
Compound 4 ended at the assay's limit; the forecaster's own chance of this, stated with the estimate: 15%; at least 50-fold (1.69 log units) between middle value and limit.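

In this assay, within the data shown here, this position, on an aromatic carbon ortho to a large group, proves sensitive: replacing cyano with the entering group of 3 heavy atoms gives an at least 300-fold higher number from compound 3 to compound 4 (2.48 log units; beyond the scatter), the first step that can be sized. For compound 4, > 4000 nM is a limit of the assay, not a number. The step is therefore only a bound: the limit of > 4000 nM in this assay, at which 2 of the 4 values shown sit.

From the compounds shown here alone, how an amine or a carboxylic acid at this position would read stays open. Methyl and trifluoromethyl cannot be compared with cyano, as compound 1 and compound 2 also differ from compound 3 in a second place.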